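This account rests on a few compounds, and the source may have more. Where it says the series, first, only, none or still open, it means among the compounds named here.

Compound 1 `N#Cc1ccc2[nH]cc(C(c3ccc(Cl)cc3)c3c[nH]c4ccc(C#N)cc34)c2c1` in a functional assay on HeLa cells (Homo sapiens) for inhibition, read by MTT assay, with a stated time of 48 h (on this read-out lower numbers stand for stronger inhibition and higher numbers for weaker inhibition), gives > 100000 nM, which is a limit of the assay rather than a number.
Compound 2 `N#Cc1ccc2[nH]cc(C(c3ccc(Br)cc3)c3c[nH]c4ccc(C#N)cc34)c2c1` in this assay gives > 100000 nM, again a limit.
Compound 3 `OC[C@H]1O[C@@H](n2cc(C(c3ccc(Cl)cc3)c3cn([C@@H]4O[C@H](CO)[C@@H](O)[C@H](O)[C@H]4O)c4ccc(Br)cc34)c3cc(Br)ccc32)[C@H](O)[C@@H](O)[C@@H]1O` in this assay gives 32000 nM.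

The step from compound 1 to compound 2 is a step that the two limits leave unreadable from compound 1 to compound 2; its size cannot be read because both values sit at the limit of > 100000 nM in this assay, at which 2 of the 3 values shown sit. The change behind it is bromo in place of chloro on an aromatic carbon. The difference between the cores of compound 1 and compound 3 is not broken down here. Compound 4 `OC[C@H]1O[C@@H](n2cc(C(c3ccc(Br)cc3)c3cn([C@@H]4O[C@H](CO)[C@@H](O)[C@H](O)[C@H]4O)c4ccc(Br)cc34)c3cc(Br)ccc32)[C@H](O)[C@@H](O)[C@@H]1O` differs from compound 3 by bromo in place of chloro on an aromatic carbon, the same change made on the core of compound 3.

For compound 4 the step is expected to be a 1.1-fold lower number from compound 3 to compound 4 (0.03 log units; within the scatter), resting on compound 3 and its value 32000 nM, since the change itself gave no readable step from compound 1 to compound 2. Compound 4 is therefore estimated at 30000 nM, between 12000 nM and 80000 nM.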

Compound 4, half-maximal inhibitory concentration: 27000 nM
The estimate for compound 4 lay 1.1-fold (0.05 log units) above the measured number; low and high end bracket the measured number.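

In this assay, replacing the 4-chlorophenyl of compound 3 with 4-bromophenyl gives a 1.2-fold lower number from compound 3 to compound 4 (0.07 log units; within the scatter), so on this core the two groups cannot be told apart. The same change on the core of compound 1 cannot be read, because compound 1 and compound 2 both give a limit of the assay rather than a number: the limit of > 100000 nM in this assay, at which 2 of the 4 values shown sit. Among these compounds, the change therefore has only one readable step, which shows no difference on the core of compound 3 but cannot show whether the result carries from one core to another.

The compounds shown carry only chloro or bromo at this place on the ring. On these data alone, what an amine or a carboxylic acid would do there remains open.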